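Ether chain cut on the aminopyridine dinitrile series

The source may report more compounds than this note shows. Statements on the series, on what has been measured and on what is new or still open speak of the compounds shown alone.

Compound 1 `N#Cc1c(N)nc(SCC(N)=O)c(C#N)c1-c1ccc(OCC2CC2)cc1` holds the lowest number of the two measured: in a functional assay on CHO cells for agonist activity at adenosine receptor A2b (Homo sapiens), read by AlphaScreen and cAMP accumulation (a lower number here means that less compound is needed, a higher number that more compound is needed for the effect), compound 1 gives 31 nM, while compound 2 `COC(=O)c1cccc(CSc2nc(N)c(C#N)c(-c3ccc(OCC4CC4)cc3)c2C#N)c1` gives 347 nM, the step of an 11-fold higher number from compound 1 to compound 2 (1.05 log units; beyond the scatter). Compound 3 `CCOc1ccc(-c2c(C#N)c(N)nc(SCC(N)=O)c2C#N)cc1` differs from compound 1 only by methyl in place of cyclopropyl on a saturated chain carbon bound to an oxygen on an aromatic ring. For the measured compounds named here, no measured step touches that ether chain; the one step known, an 11-fold higher number from compound 1 to compound 2 (1.05 log units; beyond the scatter), concerns the group on the sulfur chain and bears on it only loosely. For compound 3 a step of a 1.5-fold higher number from compound 1 to compound 3 (0.16 log units; within the scatter) is therefore expected, not clearly beyond the scatter in either direction. Compound 3 is estimated at 45 nM, with a range of 15 nM to 150 nM.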

Compound 3, half-maximal effective concentration: 38 nM
Beside the measured number, compound 3's estimate is 1.2-fold (0.07 log units) above it, and the stated range covers the measured number.
By their numbers in this assay, from the lowest: compounds 1 and 3 (each within the scatter of the next); then compound 2.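

In (this assay) the ether chain now has its first measured step (a 1.2-fold higher number from compound 1 to compound 3 (0.09 log units; within the scatter)), for methyl in place of cyclopropyl on a saturated chain carbon bound to an oxygen on an aromatic ring. With carbamoyl on the sulfur chain, the three-membered ring is therefore not required to keep the number within the scatter of compound 1. Nothing available explains this tolerance.

Still open, going by these compounds, are a longer chain such as butoxy, an amine at the end of the ether chain, and whether ethoxy is tolerated alongside the 3-(methoxycarbonyl)phenyl group of compound 2.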